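The source may report more compounds than this note shows. Statements on the series, on what has been measured and on what is new or still open speak of the compounds shown alone.

Among the compounds with values here, in a functional assay on HL-60 cells (Homo sapiens) for cytotoxicity, read by colorimetric assay and neutral red uptake, with a stated time of 72 h (on this read-out higher numbers stand for weaker inhibition and lower numbers for stronger inhibition), compound 3 (`CO[C@@H](C(=O)N[C@@H]1CCCCNC1=O)[C@H](O)[C@@H](O)[C@H](O)/C=C/C(C)(C)C`) gives 5300 nM, the only true number in the set so far. Compound 1 (`CO[C@@H](C(=O)N[C@H]1CCCCNC1=O)[C@@H]1OC(C)(C)O[C@H](/C=C/C(C)(C)C)[C@@H]1O`) reads > 150000 nM, which is a limit of the assay. Compound 2 (`CO[C@@H](C(=O)N[C@H]1CC[C@@H](O)CNC1=O)[C@H](O)[C@@H](O)[C@H](O)/C=C/C(C)(C)C`) reads > 150000 nM, also a limit.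

Compound 4 (`CO[C@@H](C(=O)N[C@@H]1CC[C@@H](O)CNC1=O)[C@H](O)[C@@H](O)[C@H](O)/C=C/C(C)(C)C`) has hydroxy in place of hydrogen on a saturated ring carbon, turning 2-oxoazepan-3-yl into 6-hydroxy-2-oxoazepan-3-yl: hydroxy in place of hydrogen on a saturated ring carbon.

Within the data shown here, one measured step bears on this change: an at least 28-fold lower number from compound 2 to compound 3 (1.45 log units; beyond the scatter). There, 2-oxoazepan-3-yl replaces 6-hydroxy-2-oxoazepan-3-yl, and the step is large and beyond the scatter. As far as these compounds go, its true size remains open because of the limit of > 150000 nM in this assay, at which 2 of the 3 values shown sit. The step to compound 4 runs the opposite way, with the hydroxy entering, so a higher number is expected in this assay. This expectation rests on a single pair, and compound 2 is not the same structure as compound 4, so the full size of that step need not carry over. The expected change is a 5.7-fold higher number from compound 3 to compound 4 (0.75 log units; beyond the scatter). A reading at the limit of the assay also remains possible.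

For compound 4 the estimated value is 30000 nM, with an expected range of 6000 nM to 150000 nM.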

Compound 4, half-maximal inhibitory concentration: 12100 nM
The estimate for compound 4 lay 2.5-fold (0.39 log units) above the measured number; low and high end bracket the measured number.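

With the hydroxy entering on a saturated ring carbon, two ring bonds from the ring nitrogen, this assay now gives this change a true size rather than an open-ended one: a 2.3-fold higher number from compound 3 to compound 4 (0.36 log units; beyond the scatter). Within the data shown here, the hydroxy is therefore tolerated at this position with only a modest loss, and compound 4 keeps a true reading, whereas the earlier compounds offered only a step from a limit. Configuration now stands out as a separate variable in the series, with an at least 12-fold lower number from compound 2 to compound 4 (1.09 log units; beyond the scatter), a stereocentre at a saturated ring carbon being drawn S in compound 2 and R in compound 4, and that step is a comparison of configuration alone: the fact that compounds 2 and 4 differ only in the configuration as drawn. As far as these compounds go, its full size remains unknown, and the reading of compound 2 stays a limit: the limit of > 150000 nM in this assay, at which 2 of the 4 values shown sit.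

The effect of the hydroxy rests on a single pair, and the compounds shown do not tell whether an amine, a methoxy or a fluorine on the same ring carbon would read like the hydroxy or like hydrogen. They also leave open how the hydroxy reads with the opposite configuration at its own ring carbon.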